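Hydroxymethyl aryl ether series: phenyl variant of the side chain

A few compounds are considered here, and "the series" means these few. Any claim that something is new, unique, unknown or untested is made for them only; others in the source may bear on it.

Measured so far:
compound 1 `Cc1cc(C(=O)O)ccc1CN1CCC[C@H](O[C@H](CO)c2cc(F)cc(F)c2)[C@@H]1c1ccccc1` — an assay on isolated protein for activation of cGMP-dependent protein kinase 1 (Homo sapiens), read by ADP-Glo, with stated times of 30 min and 2 h; on this read-out lower numbers stand for an effect already at smaller amounts and higher numbers for an effect only at larger amounts of compound: > 200000 nM
compound 2 `Cc1cc(C(=O)O)ccc1CN1CCC[C@H](O[C@H](CO)c2cccc(C(F)(F)F)c2)[C@@H]1c1ccccc1` — in this assay compound 2 gives "nd" (no result reported)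

The value of compound 1 is a limit of this assay, not a number. Going by the values given here, compound 2 carries no number in this assay at all; the only further value is the limit of > 200000 nM in this assay, at which 1 of the 2 values shown sits. Compound 3 `Cc1cc(C(=O)O)ccc1CN1CCC[C@H](O[C@H](CO)c2ccccc2)[C@@H]1c1ccccc1` differs from compound 2 by hydrogen in place of trifluoromethyl on an aromatic carbon. Among the compounds with values here, with no measured step available, the step from compound 2 to compound 3 in this assay is expected to be none beyond the scatter. Compound 3 is therefore expected at 200000 nM, within 50000 nM to 200000 nM.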

Compound 3, half-maximal effective concentration: > 200000 nM
Compound 3 gave a limit, no number; the forecaster's own chance of this, stated with the estimate: 80%; the middle value lies on the limit itself.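

No step can be read between compound 1 and compound 3: both values are limits, not numbers. The compounds shown leave open whether any aryl group on this side chain gives a measurable value.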